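The source may report more compounds than this note shows. Statements on the series, on what has been measured and on what is new or still open speak of the compounds shown alone.

For the measured compounds named here, in a functional assay on NCI-H1993 cells (Homo sapiens) for inhibition, read by CCK-8 assay, with a stated time of 72 h (on this read-out higher numbers stand for weaker inhibition and lower numbers for stronger inhibition), compound 1 `CC(c1cc2cccnc2cc1F)n1cnc2ncc(-c3ccncc3)nc21` gives 171 nM, and this is the only number available. For compound 2 `CCC(c1cc2cccnc2cc1F)n1cnc2ncc(-c3ccncc3)nc21` the entry reads "not determined" (no result reported), and for compound 3 `Cc1cc2ncccc2cc1C(C)n1cnc2ncc(-c3ccncc3)nc21` it reads "not determined" (no result reported). Compound 1 therefore cannot be ranked against either of them, and it serves as the sole reference point.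

Compound 4 `CC(c1cc2cccnc2cc1F)n1cnc2ncc(-c3ccc(C(N)=O)c(F)c3)nc21` has not yet been measured. It keeps the core of compound 1 but carries 4-carbamoyl-3-fluorophenyl in place of pyridin-4-yl on an aromatic carbon.

Going by the values given here, no step between measured compounds is available to show how this assay responds to a change at this place, so any expectation remains loose. A moderate move toward stronger inhibition is expected, although a result within the usual scatter of compound 1 would not be surprising. The estimated change is a 3.4-fold lower number from compound 1 to compound 4 (0.53 log units; beyond the scatter). For compound 4 the expected value is 50 nM, with an estimated range from 10 nM to 250 nM.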

Compound 4, half-maximal inhibitory concentration: 19.5 nM
Estimate against measurement, compound 4: 2.6-fold (0.41 log units) above; measured number inside the range.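

The position on the aromatic carbon of the shared core, next to the ring nitrogen, now has a readable step: in this assay, 4-carbamoyl-3-fluorophenyl in place of pyridin-4-yl gives an 8.8-fold lower number from compound 1 to compound 4 (0.94 log units; beyond the scatter). In this pair, the ring nitrogen of pyridin-4-yl is not needed for inhibition, since compound 4, with its carbon-only ring, gives the lower number. Nothing measured here accounts for the size of this step.

The change replaces the ring and introduces the carbamoyl and the fluorine together, so the compounds shown do not separate their contributions, and neither a plain phenyl, a 4-carbamoylphenyl without the fluorine, nor a carboxylic acid in place of the carbamoyl is among them. The changes carried by compound 2 and compound 3 cannot be read.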